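Replacing Isopropyl with Methyl on Compound 3

The compounds below may be only part of what the source reports. "The series", "measured", "known", "first", "only" and "open" are said of these compounds alone.

Compound 1 `COc1cc(F)ccc1-c1ccnc2[nH]c(C3CCN(CC(=O)N(C)C)CC3)cc12` gives 2.9
Compound 2 `CC(C)n1cc(-c2ccnc3[nH]c(C4CCN(CC(=O)N(C)C)CC4)cc23)cnc1=O` gives 0.4
Compound 3 `CC(C)n1cc(-c2ccnc3[nH]c(C4CCN(CC(=O)N(C)C)CC4)cc23)ccc1=O` gives 1.9

All three values come from a physicochemical assay for lipophilicity, using the shake flask method, measured as octanol-water partition, at pH 7.4 (on this read-out lower numbers stand for lower lipophilicity and higher numbers for higher lipophilicity), and compound 3 stands second highest, below compound 1 and above compound 2. Compound 4 `CN(C)C(=O)CN1CCC(c2cc3c(-c4ccc(=O)n(C)c4)ccnc3[nH]2)CC1` departs from compound 3 at one place methyl in place of isopropyl on an aromatic nitrogen with methyl in place of isopropyl on an aromatic nitrogen. Among the compounds with values here, no measured step makes this change, so the evidence is only indirect. The modest a number 1.00 log units lower from compound 1 to compound 3 (beyond the scatter) and the large a number 1.50 log units higher from compound 2 to compound 3 (beyond the scatter) each exchange the entire aromatic group, which shows how far this assay moves across these compounds but not what this smaller edit does. A modest downward step is therefore expected, smaller than the large one above and beyond the scatter. The expected step is a number 0.80 log units lower from compound 3 to compound 4 (beyond the scatter) and it remains an estimate. For compound 4 the estimated value is 1.1 with an expected range from 0.7 to 1.5 until it is measured.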

Compound 4, distribution coefficient: 1.1
Compound 4: middle estimate and measured number agree at the digits printed; low and high end bracket the measured number.
By their numbers in this assay, from the lowest: compound 2; then compound 4; then compound 3; then compound 1.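

Within the data shown here, compound 4 gives the first direct reading at this aromatic nitrogen: in this assay, methyl in place of isopropyl gives a number 0.80 log units lower from compound 3 to compound 4 (beyond the scatter), so this small edit alone moves the read-out beyond the scatter. With methyl on this nitrogen, the exchanges of the whole aromatic group read a number 0.70 log units higher from compound 2 to compound 4 (beyond the scatter) and a number 1.80 log units lower from compound 1 to compound 4 (beyond the scatter), and each of these steps also lies beyond the scatter. Nothing available explains the size of the step from isopropyl to methyl.

The compounds shown leave open what an ethyl group, or a longer chain ending in an amine or a carboxylic acid, would give on this nitrogen. They also leave open whether the same exchange of isopropyl for methyl on the aromatic group of compound 2 would give a step of similar size.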